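Replacing Dimethylamino with Propyl on the Shared Core

The source may report more compounds than this note shows. Statements on the series, on what has been measured and on what is new or still open speak of the compounds shown alone.

Among the measured compounds shown here, in a functional assay on the whole organism with Mus musculus as the target, in the rotarod test (a lower number here means that less compound is needed, a higher number that more compound is needed for the effect), compound 2 (`CN(C)CC(=O)NCC(=O)N(C)c1ccc(Cl)cc1C(=O)c1ccccc1Cl`) gives 26 mg/kg, the lower of the two numbers measured so far. For the measured compounds named here, the only other measured compound, compound 1 (`CCCCCCC(=O)NCC(=O)N(C)c1ccc(Cl)cc1C(=O)c1ccccc1Cl`), gives 70 mg/kg. Compound 3 (`CCCCC(=O)NCC(=O)N(C)c1ccc(Cl)cc1C(=O)c1ccccc1Cl`) keeps the shared core but carries propyl in place of dimethylamino on a saturated chain carbon bound to a carbonyl carbon. Going by the values given here, one measured step bears on this change: a 2.7-fold lower number from compound 1 to compound 2 (0.43 log units; beyond the scatter), with dimethylamino in place of pentyl at that same carbon. The change to compound 3 runs the opposite way, from dimethylamino to an alkyl chain, so a move toward a higher number is expected. Among the compounds with values here, the propyl chain is shorter than pentyl, and no measured compound shows what that difference does, so the expectation stays wide. A step of a 2.1-fold higher number from compound 2 to compound 3 (0.33 log units; beyond the scatter) is expected, similar in size to the measured one. Compound 3 is estimated at 55 mg/kg, with an expected range from 22 mg/kg to 130 mg/kg.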

Compound 3, dose for half-maximal effect: 90 mg/kg
Compound 3: middle estimate off by 1.6-fold (0.21 log units), on the low side; the measured number falls inside the stated range.
By their numbers in this assay, from the lowest: compound 2; then compounds 1 and 3 (each within the scatter of the next).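

In this assay, the earlier step rested on a single alkyl chain, and the new result shows that the lower number of compound 2 holds against a second one: a 3.5-fold higher number from compound 2 to compound 3 (0.54 log units; beyond the scatter) goes with propyl in place of dimethylamino on a saturated chain carbon bound to a carbonyl carbon. Chain length does not separate the two alkyl compounds, since a 1.3-fold higher number from compound 1 to compound 3 (0.11 log units; within the scatter) goes with hydrogen in place of ethyl on a saturated chain carbon, four bonds along the chain from a carbonyl carbon. Nothing measured here explains why dimethylamino and the alkyl chains differ at this carbon.

On these data alone, whether the lower number is particular to dimethylamino or extends to other amines, such as a piperidine, a morpholine or a primary amine, remains open. The compounds shown also leave open what a carboxylic acid or an ether would give at this carbon, and whether an alkyl chain longer than pentyl would stay level with compound 1 and compound 3.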